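Extending the Piperazine Substituent: From Cyclohexyl to Cyclohexylmethyl

The compounds below may be only part of what the source reports. "The series", "measured", "known", "first", "only" and "open" are said of these compounds alone.

Of the compounds shown here, two sharing one core have been measured in an assay on membranes from liver for displacement of a labelled ligand from Sigma intracellular receptor 2 (Rattus norvegicus), read by scintillation counting, with a stated time of 120 min; a lower number here means a stronger inhibitor, a higher number a weaker inhibitor. Compound 1 `CCN1CCN(CCC(=O)Nc2nc3c(C)cccc3s2)CC1` carries an ethyl group on the ring nitrogen of its piperazine; in this assay compound 1 gives 1200 nM. Compound 2 `Cc1cccc2sc(NC(=O)CCN3CCN(C4CCCCC4)CC3)nc12` carries a cyclohexyl group at the same place, and in this assay compound 2 gives 233 nM. Among the compounds with values here, that single swap produced a 5.2-fold lower number from compound 1 to compound 2 (0.71 log units; beyond the scatter), so compound 2 stands with the lowest number of the two, and the only neighbour is compound 1 with the higher one.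

Compound 3 `Cc1cccc2sc(NC(=O)CCN3CCN(CC4CCCCC4)CC3)nc12` is the next step: cyclohexylmethyl in place of cyclohexyl on an amine nitrogen in a ring. Within the data shown here, the one measured step that bears on this change is the move from ethyl to cyclohexyl, which gave a 5.2-fold lower number from compound 1 to compound 2 (0.71 log units; beyond the scatter); a larger ring-bearing group on this nitrogen was rewarded. Inserting one extra carbon between the ring nitrogen and the cyclohexane ring is a smaller change than that, and nothing measured here speaks against it. Compound 3 is therefore expected to show a small step in this assay, a 1.6-fold lower number from compound 2 to compound 3 (0.19 log units; within the scatter), possibly within the scatter. The estimate for compound 3 is 150 nM, with a range from 50 nM to 500 nM.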

Compound 3, inhibition constant: 519 nM
Beside the measured number, compound 3's estimate is 3.5-fold (0.54 log units) below it, and the stated range ends below it.
By their numbers in this assay, from the lowest: compound 2; then compound 3; then compound 1.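

In this assay this ring nitrogen does not simply reward a bigger group: cyclohexylmethyl in place of cyclohexyl gives a 2.2-fold higher number from compound 2 to compound 3 (0.35 log units; beyond the scatter) and so reverses the direction of the earlier gain. Compound 3 still keeps part of the gain over the ethyl group of compound 1, as the comparison with that compound shows a 2.3-fold lower number from compound 1 to compound 3 (0.36 log units; beyond the scatter) and places the cyclohexylmethyl group in the middle of the three. The outcome at this position therefore depends on how the cyclohexane ring is attached and not only on the presence of the ring, since the group with more carbon atoms gives the higher number of the two ring-bearing compounds. No measurement available here explains why the extra carbon has this effect.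

Still open, going by these compounds, is whether a longer chain, such as cyclohexylethyl, would raise the number further or bring it back down. On these data alone, it is also open whether a smaller ring joined directly to the nitrogen, such as cyclopentyl, or a flat phenyl ring in place of the cyclohexane would keep the lower number seen with compound 2.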